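This account rests on a few compounds, and the source may have more. Where it says the series, first, only, none or still open, it means among the compounds named here.

In a physicochemical assay for solubility, measured as kinetic solubility (on this read-out higher numbers stand for higher solubility and lower numbers for lower solubility), compound 1 (`Cc1cnc(NC(=O)c2cc(Oc3ccc(C(=O)N(C)C)nc3)c3cc(C)oc3c2)cn1`) gives 418000 nM and compound 2 (`Cc1cnc(NC(=O)c2cc(Oc3ncc(C(=O)N(C)C)cn3)c3cc(C)oc3c2)cn1`) gives 485000 nM as its number, two results within the scatter of each other. Compound 3 (`Cc1cc2c(Oc3cnc(C(=O)N4CC(C)C4)cn3)cc(C(=O)Nc3cnccn3)cc2o1`) stands lowest of the three, at 49000 nM as measured, clearly beyond the scatter from both. Compound 4 (`COC1CN(C(=O)c2cnc(Oc3cc(C(=O)Nc4cnccn4)cc4oc(C)cc34)cn2)C1`) differs from compound 3 in one place, where 3-methylazetidin-1-yl becomes 3-methoxyazetidin-1-yl (methoxy in place of methyl on a saturated ring carbon): methoxy in place of methyl on a saturated ring carbon. Within the data shown here, no measured pair shows this change, so any forecast stays loose. A moderate rise in this assay is expected, somewhat beyond the scatter. The expected step is a 2.2-fold higher number from compound 3 to compound 4 (0.35 log units; beyond the scatter) in the upward direction. Compound 4 is estimated at 110000 nM with an expected range from 45000 nM to 280000 nM in this read-out.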

Compound 4, solubility: 158000 nM
For compound 4 the middle estimate is 1.4-fold (0.16 log units) below the measured one; measured number inside the range.
By their numbers in this assay, from the lowest: compound 3; then compound 4; then compounds 1 and 2 (each within the scatter of the next).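

In this assay, among these compounds, the change from 3-methylazetidin-1-yl to 3-methoxyazetidin-1-yl gives a 3.2-fold higher number from compound 3 to compound 4 (0.51 log units; beyond the scatter) and is the first direct reading of a change at this saturated ring carbon, two ring bonds from the ring nitrogen. The number at this position can therefore move beyond the scatter when methoxy replaces methyl, a swap that adds one oxygen and one hydrogen-bond acceptor. Nothing available explains this rise. On these data alone, it remains open how an amine, a hydroxyl or a carboxylic acid on this ring carbon would read. As far as these compounds go, whether the same swap gives a similar step on another core also remains open.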